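Working notes on cytotoxicity across one small series

The source may hold more compounds than are shown below. What is called first, only, known or untested is meant among the compounds shown, and "the series" means these compounds.

Measured so far in an ADME assay on Vero cells (Chlorocebus sabaeus) for cytotoxicity, read by MTT assay, with a stated time of 72 h; on this read-out higher numbers stand for lower toxicity in this test and lower numbers for higher toxicity in this test:
compound 1 `O=C(COc1ccccc1C(=O)/C=C/c1ccc(Cl)cc1)NCCNc1ccnc2cc(Cl)ccc12` gives 4980 nM;
compound 2 `COc1ccc(/C=C/C(=O)c2ccccc2OCC(=O)NCCNc2ccnc3cc(Cl)ccc23)cc1` gives 25000 nM.

Compound 2 stands highest of the two numbers in this assay; the nearest is compound 1, with a 5.0-fold higher number from compound 1 to compound 2 (0.70 log units; beyond the scatter).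

Compound 3 `COc1cc(OC)c(OC)cc1/C=C/C(=O)c1ccccc1OCC(=O)NCCNc1ccnc2cc(Cl)ccc12` is not yet measured. It differs from compound 2 by 2,4,5-trimethoxyphenyl in place of 4-methoxyphenyl on a double-bonded chain carbon bound to a double-bonded chain carbon. Among the measured compounds shown here, only the step from compound 1 to compound 2 touches the same ring, and no measured pair shows further methoxy groups added to a ring that already carries one. For compound 3 the expected step is therefore small, a 1.2-fold higher number from compound 2 to compound 3 (0.08 log units; within the scatter), close to the scatter. Compound 3 is estimated at 30000 nM, range 10000 nM to 90000 nM.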

Compound 3, half-maximal cytotoxic concentration: 12300 nM
Estimate against measurement, compound 3: 2.4-fold (0.39 log units) above; the measured number falls inside the stated range.
By their numbers in this assay, from the lowest: compound 1; then compound 3; then compound 2.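

In this assay, 2,4,5-trimethoxyphenyl in place of 4-methoxyphenyl on this chain carbon does not extend the earlier gain, giving a 2.0-fold lower number from compound 2 to compound 3 (0.31 log units; beyond the scatter) as the result. Compared with 4-chlorophenyl, the same group still gives a 2.5-fold higher number from compound 1 to compound 3 (0.39 log units; beyond the scatter) at this place, so the number does not rise in step with the count of methoxy groups, and compound 3 goes against such a trend. No measured evidence bears on the reason for either step.

From the compounds shown here alone, it remains open whether the drop from 4-methoxyphenyl follows from the number of methoxy groups or from their arrangement in 2,4,5-trimethoxyphenyl. Going by these compounds, how a hydroxy group or an amine on this ring would read in this test also remains open.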